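A few compounds are considered here, and "the series" means these few. Any claim that something is new, unique, unknown or untested is made for them only; others in the source may bear on it.

- Compound 1 `O=C(CCCCC1CCSS1)Nc1ccc(Cl)cn1`: 2%
- Compound 2 `O=C(CCCCC(S)CCS)Nc1ccccn1`: "not determined" (no result reported)

Among the measured compounds shown here, in a functional assay on PC-3 cells (Homo sapiens) for inhibition, read by MTT assay, with a stated time of 24 h, tested at 1 ug/mL (on this read-out higher numbers stand for more inhibition of growth at the one concentration tested and lower numbers for less inhibition of growth), compound 1 gives 2%, the only number so far. Compound 2 stands at "not determined" (no result reported), so it offers no single number as a starting point. Compound 3 `O=C(CCCCC(S)CCS)Nc1ccc(Cl)cn1` is the chloro counterpart of compound 2, and the change reads chloro in place of hydrogen on an aromatic carbon. For the measured compounds named here, with no measured step to go on, no step beyond the scatter is expected in this assay, and the expectation stays near compound 1 at 2%. The estimate for compound 3 is 6%, with an expected range of 0% to 25%.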

Compound 3, percent growth inhibition at one concentration: 0.89%
Compound 3: the middle estimate sits 5.1 percentage points above what was measured, and the stated range covers the measured number.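

In this assay, the open group with no ring in place of the group with one five-membered non-aromatic ring gives a number 1.1 percentage points lower from compound 1 to compound 3 (within the scatter), so on this read-out the ring and open forms at this saturated chain carbon are not told apart. The step for chloro in place of hydrogen cannot be read, as compound 2 has no number. No available data bear on a cause for this result.

Still open, from the compounds shown here alone, is whether an amine or a methoxy group at the aromatic carbon would shift the number. Also open, going by these compounds, is what a longer chain would do at the saturated chain carbon.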